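Piperazine to Piperidine Swap and Rat Half-Life

A few compounds are considered here, and "the series" means these few. Any claim that something is new, unique, unknown or untested is made for them only; others in the source may bear on it.

Compound 1 `COc1cc2nnc(C(N)=O)c(Nc3ccc(C)cc3F)c2cc1N1CCN(C)CC1` gives 5.7 h in an ADME assay on the whole organism for metabolic stability, with Rattus norvegicus as the target; a lower number here means that the compound disappears faster, a higher number that the compound lasts longer.
Compound 2 `COc1cc2nnc(C(N)=O)c(Nc3ccc(C)cc3F)c2cc1N1CCN(C(C)C)CC1` gives 2.5 h in this assay.
Compound 3 `COc1cc2nnc(C(N)=O)c(Nc3ccc(C)cc3F)c2cc1N1C[C@@H](C)N[C@@H](C)C1` gives 4.4 h in this assay.

Among the three measured compounds, compound 3 stands second highest in this assay. Its nearest neighbour is compound 1, and the gap between the two is within the scatter; against compound 2 there is a 1.8-fold higher number from compound 2 to compound 3 (0.25 log units; within the scatter).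

Compound 4 `COc1cc2nnc(C(N)=O)c(Nc3ccc(C)cc3F)c2cc1N1CCC(N(C)C)CC1` differs from compound 3 in one place: 4-(dimethylamino)piperidin-1-yl in place of 3,5-dimethylpiperazin-1-yl on an aromatic carbon. Going by the values given here, no measured step covers this exact change. Among the compounds with values here, two steps bear on it indirectly. The step of a 1.3-fold lower number from compound 1 to compound 3 (0.11 log units; within the scatter) shows that exchanging one substituted piperazine for another left the number essentially unchanged. The step of a 2.3-fold lower number from compound 1 to compound 2 (0.36 log units; beyond the scatter) shows that enlarging the alkyl on the ring amine nitrogen brought a modest loss. Compound 4 carries a dimethylamino group rather than a larger alkyl, so the second step argues for at most a small shift.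

Compound 4 is therefore expected to show a step of a 1.3-fold lower number from compound 3 to compound 4 (0.10 log units; within the scatter), within the scatter. The estimate for compound 4 in this assay is 3.5 h, with a range from 1.7 h to 7 h.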

Compound 4, half-life: 0.9 h
Beside the measured number, compound 4's estimate is 3.9-fold (0.59 log units) above it; the whole stated range lies above it.
By their numbers in this assay, from the lowest: compound 4; then compounds 2, 3 and 1 (each within the scatter of the next, the first and the last beyond it).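

In this assay, going by these compounds alone, the position on the aromatic carbon ortho to a methoxy group responds more strongly to this change than the earlier compounds suggested: 4-(dimethylamino)piperidin-1-yl in place of 3,5-dimethylpiperazin-1-yl gives a 4.9-fold lower number from compound 3 to compound 4 (0.69 log units; beyond the scatter) in this comparison. The same direction holds against the other two piperazines, with a 6.3-fold lower number from compound 1 to compound 4 (0.80 log units; beyond the scatter) against the 4-methylpiperazin-1-yl and a 2.8-fold lower number from compound 2 to compound 4 (0.44 log units; beyond the scatter) against the 4-isopropylpiperazin-1-yl. All three piperazines shown therefore stand beyond the scatter above compound 4, and none goes against this within the set.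

Nothing available here accounts for the shorter half-life of compound 4 and the question stays open. The compounds shown also do not separate the piperidine ring from its dimethylamino group, which a morpholine or a 4-methylpiperidine at this position could help to tell apart.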